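The source may report more compounds than this note shows. Statements on the series, on what has been measured and on what is new or still open speak of the compounds shown alone.

Compound 3 `C=CC(=O)Nc1cccc(NC(=O)CSc2nc(Nc3ccccc3F)c3ccccc3n2)c1` gives 9340 nM in a functional assay on PC-3 cells (Homo sapiens) for inhibition, read by MTT assay, with a stated time of 72 h; a higher number here means a weaker inhibitor, a lower number a stronger inhibitor.
Compound 1 `CCc1cccc(NC(=O)CSc2nc(Nc3ccccc3)c3ccccc3n2)c1` gives 11000 nM in this assay.
Compound 2 `CCc1ccc(NC(=O)CSc2nc(Nc3ccccc3)c3ccccc3n2)cc1` gives 17900 nM in this assay.

Compound 3 stands on the lowest of the three numbers, but its gaps to compound 1 and to compound 2 both lie within the scatter, so the three measured compounds cannot be told apart on these data. Among the measured compounds shown here, the one step between measured compounds is a 1.6-fold higher number from compound 1 to compound 2 (0.21 log units; within the scatter), which concerns the ethyl group on an amide-type nitrogen and stays within the scatter.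

Compound 4 `C=CC(=O)Nc1cccc(NC(=O)CSc2nc(Nc3cccc(C)c3)c3ccccc3n2)c1` differs from compound 3 by 3-methylphenyl in place of 2-fluorophenyl on a nitrogen on an aromatic ring. For the measured compounds named here, no measured pair shows this change, and the step from compound 1 to compound 2 sits on a different part of the shared core, so it gives only a general sense that a small change on a phenyl ring has not moved the number beyond the scatter. Compound 4 is therefore expected to stay close to compound 3, with a step of a 1.0-fold higher number from compound 3 to compound 4 (0.01 log units; within the scatter) that is expected to fall within the scatter. The estimate for compound 4 is 9500 nM, expected between 4000 nM and 25000 nM.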

Compound 4, half-maximal inhibitory concentration: 29200 nM
Beside the measured number, compound 4's estimate is 3.1-fold (0.49 log units) below it; measured number outside the range, above it.
By their numbers in this assay, from the lowest: compounds 3, 1, 2 and 4 (each within the scatter of the next, the first and the last beyond it).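

Among the compounds shown here, with the step of a 3.1-fold higher number from compound 3 to compound 4 (0.50 log units; beyond the scatter) in this assay the series shows its only single change that passes beyond the scatter, so the aryl group on this nitrogen on an aromatic ring can move the number, which the ethyl step between the earlier compounds did not show. The change is modest, and the counts of heavy atoms and the carbon-only aromatic ring stay the same on both sides. Nothing at hand bears on why the number moved.

The compounds shown leave open whether the step follows the loss of the fluorine, the arrival of the methyl group or the different numbering of the two groups on the phenyl ring. Also open, from the compounds shown here alone, is how 3-fluorophenyl, 2-methylphenyl or a phenyl ring carrying a methoxy group or an amine would stand against compound 3.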